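A few compounds are considered here, and "the series" means these few. Any claim that something is new, unique, unknown or untested is made for them only; others in the source may bear on it.

Compound 1, `COc1cc(-n2ncnc2-c2ccc(F)cc2)cc(OC)c1OC`: > 10000 nM
Compound 2, `COc1cc(-n2ncnc2-c2ccccc2)cc(OC)c1OC`: > 10000 nM
Compound 3, `CCOc1ccc(-c2ncnn2-c2cc(OC)c(OC)c(OC)c2)cc1Cl`: 3 nM

Of the compounds shown here, three built on a shared core have been tested in a functional assay on Jurkat cells (Homo sapiens) for antiproliferative activity, read by MTT assay, with a stated time of 72 h; a lower number here means a stronger inhibitor, a higher number a weaker inhibitor. For compound 1 the reading is a limit of the assay and not a number, > 10000 nM. For compound 2 the reading is likewise a limit, > 10000 nM. Among the measured compounds shown here, compound 3 gives 3 nM, the only real number among the three; the other two readings sit at the limit of > 10000 nM in this assay, at which 2 of the 3 values shown sit. For the measured compounds named here, the single pair differing in one place is a step that the two limits leave unreadable from compound 1 to compound 2. Both of its readings are limits, so the size of that step cannot be read.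

Compound 4, `CCOc1ccc(-c2ncnn2-c2cc(OC)c(OC)c(OC)c2)cc1`, has not yet been measured in this assay. Relative to compound 3 the change is hydrogen in place of chloro on an aromatic carbon. Going by the values given here, no measured step shows what removing a chloro does here: the one step that exists is unreadable and concerns a fluoro, not a chloro. The expectation therefore rests on compound 3 alone, with wide uncertainty. Compound 4 is expected to give about 30 nM, within a range from 5 nM to 300 nM. The step this estimate means, a 10-fold higher number from compound 3 to compound 4 (1.00 log units; beyond the scatter), is expected to be a moderate weakening, though a result within the scatter cannot be excluded.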

Compound 4, half-maximal inhibitory concentration: 5 nM
Beside the measured number, compound 4's estimate is 6.0-fold (0.78 log units) above it; low and high end bracket the measured number.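

Losing the chloro does not register here: a 1.7-fold higher number from compound 3 to compound 4 (0.22 log units; within the scatter), so on this ring, at a carbon ortho to an ethoxy group, hydrogen and chloro cannot be told apart in this cell assay. Among the compounds shown here, the large difference instead goes with the ethoxy group, which the earlier compounds could not show, since the only step among them was unreadable: an at least 2000-fold lower number from compound 2 to compound 4 (3.30 log units; beyond the scatter), and replacing fluoro gives a matching result, an at least 2000-fold lower number from compound 1 to compound 4 (3.30 log units; beyond the scatter). Compound 1 and compound 2 each give a limit and not a number, so these two steps set only a minimum size and the step between those two compounds cannot be read: the limit of > 10000 nM in this assay, at which 2 of the 4 values shown sit.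

On these data alone, what stays open is whether the effect depends on the ethoxy group itself, since a methoxy, a longer chain such as propoxy, or a hydroxyl in its place would each test how much of that group is needed. As far as these compounds go, it is also open how a methyl or a nitrile would read where the chloro sits, given that only chloro and hydrogen appear at that carbon.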